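Methoxy for methyl in a chalcone amide: cytotoxicity outlook

This account rests on a few compounds, and the source may have more. Where it says the series, first, only, none or still open, it means among the compounds named here.

Compound 1 `COC(=O)c1cc(-c2cccc(NC(=O)c3ccc(/C=C/C(=O)c4ccc(F)cc4)cc3)c2)on1` gives > 20 ug/mL in an ADME assay on Vero cells (Chlorocebus sabaeus) for cytotoxicity, read by MTT assay, with a stated time of 72 h (on this read-out lower numbers stand for higher toxicity in this test and higher numbers for lower toxicity in this test), which is a limit of the test and not a number.
Compound 2 `COC(=O)c1cc(-c2cccc(NC(=O)c3ccc(/C=C/C(=O)c4ccc(C)cc4)cc3)c2)on1` gives > 80 ug/mL in this assay, likewise only a limit.

Compound 2 thus stands at a limit (the limit of > 80 ug/mL in this assay, at which 1 of the 2 values shown sits). For the measured compounds named here, the only measured step, a step that the two limits leave unreadable from compound 1 to compound 2, cannot be sized, since compound 1 also sits at a limit (the limit of > 20 ug/mL in this assay, at which 1 of the 2 values shown sits). Compound 3 `COC(=O)c1cc(-c2cccc(NC(=O)c3ccc(/C=C/C(=O)c4ccc(OC)cc4)cc3)c2)on1` differs from compound 2 by methoxy in place of methyl on an aromatic carbon. Going by the values given here, no measured step bears on this change with a readable size. Compound 3 is therefore expected to show no step beyond the scatter, a number no higher from compound 2 to compound 3 (the limit leaves the size open), with an estimate of 80 ug/mL (range 30 ug/mL to 200 ug/mL), most likely again reported only as a limit.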

Compound 3, half-maximal cytotoxic concentration: > 10 ug/mL
Compound 3: only a limit was reported; the forecaster's own chance of this, stated with the estimate: 70%; the middle value does not contradict the limit.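

In this assay, for the compounds shown here, compound 1, compound 2 and compound 3 each gave only a limit and not a number, so no step among them can be read. Going by these compounds, whether fluoro, methyl or methoxy on this aromatic carbon changes the toxicity at all stays open.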